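A few compounds are considered here, and "the series" means these few. Any claim that something is new, unique, unknown or untested is made for them only; others in the source may bear on it.

Compound 1 `CC(C)CNC(=O)Cn1sc2ccccc2c1=O` sits second highest of three numbers in an assay on isolated protein for inhibition of histone acetyltransferase p300 (Homo sapiens), read by fluorescence, with a stated time of 10 min, tested at 50 uM (on this read-out higher numbers stand for more inhibition at the one concentration tested (going by the name of the read-out) and lower numbers for less inhibition), where compound 1 gives 54.6%. Compound 2 `CCCCc1ccc(-n2sc3ncc(-c4ccccc4)cc3c2=O)cc1` gives 68% in this assay, a number above compound 1 by more than the usual scatter. Compound 3 `O=C(O)CCCn1sc2ccccc2c1=O` gives 8.8% in this assay, far below compound 1. Compound 4 `COCCNC(=O)Cn1sc2ccccc2c1=O` has not yet been measured. It differs from compound 1 in one place: methoxymethyl in place of isopropyl on a saturated chain carbon bound to an amide-type nitrogen. Among the measured compounds shown here, no measured pair shows this kind of change, so the step is judged from the size of the group alone. A step within the scatter is expected from compound 1 to compound 4, a number 4.6 percentage points lower from compound 1 to compound 4 (within the scatter), and compound 4 is therefore estimated at 50% in this assay, within a range from 30% to 70%.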

Compound 4, a percentage reported as inhibition, at one concentration (the size of the read-out at that concentration, not a potency): 45.1%
Compound 4: middle estimate off by 4.9 percentage points, on the high side; measured number inside the range.
By their numbers in this assay, from the lowest: compound 3; then compounds 4 and 1 (each within the scatter of the next); then compound 2.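

Among the compounds shown here, this is the first measured change at this place, on a saturated chain carbon bound to an amide-type nitrogen. In this assay, methoxymethyl in place of isopropyl adds one hydrogen-bond acceptor and gives a number 9.5 percentage points lower from compound 1 to compound 4 (within the scatter), so an oxygen in this chain leaves the number unchanged within the scatter. No measurement here accounts for this result. Still open, as far as these compounds go, is whether an amine, a phenyl ring or a longer chain at this place would keep the number or shift it beyond the scatter.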